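The source may hold more compounds than are shown below. What is called first, only, known or untested is meant among the compounds shown, and "the series" means these compounds.

The compounds share one core, and three of them have been tested in an ADME assay on HCT-116 cells (Homo sapiens) for cytotoxicity, read by MTT assay, with a stated time of 72 h; on this read-out lower numbers stand for stronger inhibition and higher numbers for weaker inhibition. Compound 1 `CCc1ccc(NC(=O)c2cccc(/C=C3\CC(=O)N(c4ccccc4)C3=O)c2)cc1` gives only a limit there: in this assay compound 1 reads > 100000 nM, which is a limit of the assay and not a number. Compound 3 `Cc1ccc(N2C(=O)C/C(=C\c3cccc(C(=O)Nc4ccc(Cl)cc4)c3)C2=O)cc1` likewise sits at a limit, reading > 100000 nM in this assay. Among the measured compounds shown here, compound 2 `CCCCCN1C(=O)C/C(=C\c2cccc(C(=O)Nc3cccc(CC)c3)c2)C1=O` is the only member with a measured number: in this assay compound 2 gives 75300 nM. Compound 1 thus stands at the limit of > 100000 nM in this assay, at which 2 of the 3 values shown sit, and on these numbers nothing separates it from compound 3, while compound 2 differs only in returning a value at all.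

Compound 4 `O=C(c1cccc(/C=C2\CC(=O)N(c3ccccc3)C2=O)c1)N1CCCC1` is not yet measured. It differs from compound 1 in one place: pyrrolidin-1-yl in place of (4-ethylphenyl)amino on a carbonyl carbon. For the measured compounds named here, no step between measured compounds is available to calibrate this change, and all three measured values lie at or close to the upper edge of the tested range. The expected step is a number no higher from compound 1 to compound 4 (the limit leaves the size open), nothing beyond the scatter. Compound 4 is expected to give about 100000 nM in this assay, within a range from 40000 nM to 300000 nM, with a good chance that only a limit is again reported.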

Compound 4, half-maximal inhibitory concentration: > 100000 nM
Compound 4: a limit, no number (the forecaster's own chance of this, stated with the estimate: 60%); the middle value sits exactly at the limit.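

In this assay compound 4 gives > 100000 nM, which is a limit of the assay and not a number. Among the compounds shown here, compound 1 also sits at a limit, so no step between compound 1 and compound 4 can be read. The compounds shown leave open whether pyrrolidin-1-yl in place of (4-ethylphenyl)amino on a carbonyl carbon changes the read-out at all: the limit of > 100000 nM in this assay, at which 3 of the 4 values shown sit.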